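Adding chloro to compound 1: what to expect

The source may report more compounds than this note shows. Statements on the series, on what has been measured and on what is new or still open speak of the compounds shown alone.

In an ADME assay on HeLa cells (Homo sapiens) for cytotoxicity, read by resazurin assay, with a stated time of 2 days (on this read-out higher numbers stand for weaker inhibition and lower numbers for stronger inhibition), compound 1 (`Cn1c([N+](=O)[O-])cnc1/C=C/c1ccccc1`) gives > 100000 nM as a limit of the assay, not a number. Compound 3 (`Cn1c([N+](=O)[O-])cnc1/C=C/c1ccccc1Cl`) differs from compound 1 at one place (chloro in place of hydrogen on an aromatic carbon) with chloro in place of hydrogen on an aromatic carbon, ortho to a large group. Going by the values given here, only one measured step bears on this, and it involves a different group. Compound 2 (`Cc1cccc(/C=C/c2ncc([N+](=O)[O-])n2C)c1`) gives 30900 nM and its change, methyl in place of hydrogen on an aromatic carbon, amounts to an at least 3.2-fold lower number from compound 1 to compound 2 (0.51 log units; beyond the scatter) overall. A similar move toward stronger inhibition is therefore expected, an estimated at least 2.5-fold lower number from compound 1 to compound 3 (0.39 log units; beyond the scatter) in all. Compound 3 is expected at 40000 nM (range 12000 nM to 100000 nM).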

Compound 3, half-maximal inhibitory concentration: > 100000 nM
Compound 3: a limit, no number (the forecaster's own chance of this, stated with the estimate: 35%); middle value at least 2.5-fold (0.39 log units) away from the limit.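

No step can be read between compound 1 and compound 3, because both stop at the same limit, which is not a number: the limit of > 100000 nM in this assay, at which 2 of the 3 values shown sit.

Going by these compounds, whether chloro in place of hydrogen on an aromatic carbon shifts the result in this assay at all, and by how much, stays open.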